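The source may report more compounds than this note shows. Statements on the series, on what has been measured and on what is new or still open speak of the compounds shown alone.

In an ADME assay on a cell-free system (plasma, Mus musculus) for metabolic stability, read by LC-MS, tested at 2 uM (on this read-out higher numbers stand for a longer-lived compound and lower numbers for a shorter-lived compound), compound 1 `O=C(NCCCCc1ccccc1)n1cc(-c2ccccc2)oc1=O` gives only a limit of the assay, < 0.0834 h. Among the compounds with values here, compound 2 `O=C(NCCCCc1ccccc1)n1cc(-c2ccncc2)oc1=O` gives 0.5 h, the only actual number so far. Compound 3 `O=C(NCCCCc1ccccc1)n1cc(-c2cnccn2)oc1=O` carries pyrazin-2-yl in place of pyridin-4-yl on an aromatic carbon. Within the data shown here, the one measured guide is an at least 5.9-fold higher number from compound 1 to compound 2 (0.77 log units; beyond the scatter), which replaced phenyl and rests on (the limit of < 0.0834 h in this assay, at which 1 of the 2 values shown sits). Here, one aromatic ring with hetero atoms replaces another, so a smaller change is expected. The estimated change is a 1.2-fold higher number from compound 2 to compound 3 (0.08 log units; within the scatter), with nothing expected beyond the scatter. For compound 3, the expected half-life is 0.6 h, with an estimated range of 0.17 h to 2 h.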

Compound 3, half-life in the Mus musculus assay: 0.667 h
For compound 3 the middle estimate is 1.1-fold (0.05 log units) below the measured one, and the stated range covers the measured number.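

In the Mus musculus assay, pyrazin-2-yl in place of pyridin-4-yl gives a 1.3-fold higher number from compound 2 to compound 3 (0.13 log units; within the scatter), so these two rings are not told apart at this position. In the Mus musculus assay, a second ring with hetero atoms also stands clear of phenyl, with an at least 7.9-fold higher number from compound 1 to compound 3 (0.90 log units; beyond the scatter), a size that rests on a limit: the limit of < 0.0834 h in the Mus musculus assay, at which 1 of the 3 values shown sits. In a physicochemical assay for solubility, read by HPLC, in phosphate buffer, measured as kinetic solubility, with a stated time of 1 h, at pH 7.4, tested at 250 uM (on this read-out higher numbers stand for higher solubility and lower numbers for lower solubility), compound 2 gives < 1000 nM as a limit of the assay. In the physicochemical assay compound 3 gives < 1000 nM as a limit of the assay. In the physicochemical assay, the step from compound 2 to compound 3 cannot be read: the limit of < 1000 nM in the physicochemical assay, at which 2 of the 2 values shown sit.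

Going by these compounds, whether a non-aromatic group at this position, such as an amine or a carboxylic acid, would give a longer half-life remains open.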